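Swapping a propyl chain end for dimethylamino

A few compounds are considered here, and "the series" means these few. Any claim that something is new, unique, unknown or untested is made for them only; others in the source may bear on it.

Compound 1 `COc1cc(C(=O)c2cccc3cc[nH]c23)cc(OC)c1OC`: 284 nM
Compound 2 `CCCn1ccc2cc(C(=O)c3cc(OC)c(OC)c(OC)c3)ccc21`: 2100 nM

Both values come from a functional assay (Homo sapiens) for inhibition, with a stated time of 72 h (a lower number here means a stronger inhibitor, a higher number a weaker inhibitor), as the test. Compound 2 has the higher of the two numbers, which makes it the weaker inhibitor, and its gap to compound 1 lies beyond the scatter. Compound 3 `COc1cc(C(=O)c2ccc3c(ccn3CCN(C)C)c2)cc(OC)c1OC` differs from compound 2 in one place. The change dimethylamino in place of methyl on a saturated chain carbon, two bonds along the chain from an aromatic nitrogen puts dimethylamino in place of methyl on a saturated chain carbon, two bonds along the chain from an aromatic nitrogen. Among the compounds with values here, no measured pair shows this kind of change, so no step beyond the scatter is expected in this assay on present evidence. The estimated step of a 1.4-fold lower number from compound 2 to compound 3 (0.15 log units; within the scatter) is slight, toward a lower number. Compound 3 is expected at 1500 nM (range 400 nM to 5000 nM).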

Compound 3, half-maximal inhibitory concentration: 4900 nM
Compound 3: middle estimate off by 3.3-fold (0.51 log units), on the low side, within the range that was stated.
By their numbers in this assay, from the lowest: compound 1; then compound 2; then compound 3.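

Swapping propyl for 2-(dimethylamino)ethyl gives a 2.3-fold higher number from compound 2 to compound 3 (0.37 log units; beyond the scatter) in this assay, so inhibition gets weaker by more than the usual scatter. The end of this chain is therefore not indifferent to this change, although the step is modest. No available measurement explains the rise. From the compounds shown here alone, it remains open whether a longer chain would follow the same direction. The effect of a carboxylic acid or a morpholine at the chain end is also unknown.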